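A few compounds are considered here, and "the series" means these few. Any claim that something is new, unique, unknown or untested is made for them only; others in the source may bear on it.

Working notes on the aryl ether series.

Three compounds have a number in a physicochemical assay for lipophilicity, in phosphate buffer, measured as octanol-water partition; a higher number here means a more lipophilic compound, a lower number a more polar compound. Compound 1 `CCCc1nc2ccccc2c(=O)n1/N=C/c1ccc(Oc2ccc3ccccc3c2)cc1` gives 6.12. Compound 2 `O=c1c2ccccc2nc(-c2ccccc2)n1/N=C/c1ccc(Oc2ccccc2)cc1` gives 6.13. Compound 3 `CCCc1nc2ccccc2c(=O)n1/N=C/c1ccc(Oc2ccccc2)cc1` gives 5.2. Two single-point steps connect them: a number 0.92 log units lower from compound 1 to compound 3 (beyond the scatter), and a number 0.93 log units lower from compound 2 to compound 3 (beyond the scatter). Compound 2 holds the highest of the three numbers, with compound 1 lying within the scatter of it and compound 3 clearly apart from it.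

Compound 4 `O=c1c2ccccc2nc(-c2ccccc2)n1/N=C/c1ccc(Oc2ccc(Cl)cc2)cc1` is the next member and differs from compound 2 in one place: chloro in place of hydrogen on an aromatic carbon, on an aromatic carbon of a six-membered aromatic ring of carbon only, para to a large group, so that phenoxy becomes 4-chlorophenoxy. Going by the values given here, neither measured step introduces a chloro group, so no step reports this change directly; both steps, from compound 1 to compound 3 and from compound 2 to compound 3, were modest in size and shifted this assay in one direction only. By analogy a modest step upward is expected for compound 4, a number 0.57 log units higher from compound 2 to compound 4 (beyond the scatter). Compound 4 is therefore estimated at 6.7, within 6.3 to 7.1.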

Compound 4, partition coefficient: 6.38
For compound 4 the middle estimate is 0.32 log units above the measured one, and the stated range covers the measured number.
By their numbers in this assay, from the lowest: compound 3; then compounds 1, 2 and 4 (each within the scatter of the next).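

In this assay the step that puts chloro in place of hydrogen on an aromatic carbon, para to a large group, turning phenoxy into 4-chlorophenoxy, is a number 0.25 log units higher from compound 2 to compound 4 (within the scatter) and so does not separate the two compounds. Going by these compounds alone, the two earlier steps, a number 0.92 log units lower from compound 1 to compound 3 (beyond the scatter) and a number 0.93 log units lower from compound 2 to compound 3 (beyond the scatter), each lay beyond the scatter and involved larger changes of group, so this is the first single-place change whose step stays within the scatter. Nothing measured alongside these numbers accounts for the size of this step.

Going by these compounds, whether an amine, a carboxylic acid or a methoxy group at this same position would give a step beyond the scatter remains open. Also open, on these data alone, is whether chloro gives a similar step on compound 3, which carries propyl in place of phenyl.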